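Chloro in Place of Hydrogen, Expected Near Its Bromo Counterpart

The source may hold more compounds than are shown below. What is called first, only, known or untested is meant among the compounds shown, and "the series" means these compounds.

Compound 1 `COc1cc(-c2cccc3nc(-c4ccccc4)oc23)cc(OC)c1OC`: in a functional assay on NCI-H460 cells (Homo sapiens) for antiproliferative activity, read by MTT assay, with a stated time of 48 h (on this read-out higher numbers stand for weaker inhibition and lower numbers for stronger inhibition), compound 1 gives 6800 nM.
Compound 2 `COc1cccc(-c2nc3cccc(-c4cc(OC)c(OC)c(OC)c4)c3o2)c1`: in this assay compound 2 gives > 25000 nM, which is a limit of the assay and not a number.
Compound 3 `COc1cc(-c2cccc3nc(-c4cccc(Br)c4)oc23)cc(OC)c1OC`: in this assay compound 3 gives 3800 nM.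

Compound 1 holds the highest of the two numbers shown, and its nearest neighbour is compound 3, with a 1.8-fold lower number from compound 1 to compound 3 (0.25 log units; within the scatter). The third value shown, that of compound 2, sits at the limit of > 25000 nM in this assay, at which 1 of the 3 values shown sits.

Compound 4 `COc1cc(-c2cccc3nc(-c4cccc(Cl)c4)oc23)cc(OC)c1OC` has not yet been measured. It differs from compound 1 by chloro in place of hydrogen on an aromatic carbon.

Going by the values given here, only one measured step bears on this change: a 1.8-fold lower number from compound 1 to compound 3 (0.25 log units; within the scatter), where bromo replaced hydrogen at the same place. The other two steps, an at least 3.6-fold higher number from compound 1 to compound 2 (0.56 log units; beyond the scatter) and an at least 6.5-fold lower number from compound 2 to compound 3 (0.81 log units; beyond the scatter), involve a methoxy group that plays no part here. Chloro, like bromo, is a single halogen atom at the same place, so the expected step in this assay is small and, if anything, towards a lower number.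

The expected step is a 1.5-fold lower number from compound 1 to compound 4 (0.18 log units; within the scatter). Compound 4 is therefore estimated at 4500 nM, with a range from 2000 nM to 10000 nM.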

Compound 4, half-maximal inhibitory concentration: > 25000 nM
Compound 4 gave a limit, no number (the forecaster's own chance of this, stated with the estimate: 3%); middle value at least 5.5-fold (0.74 log units) away from the limit.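

In this assay, this position proves far more sensitive to a single-atom change than compound 3 suggested: going from phenyl to 3-chlorophenyl gives an at least 3.6-fold higher number from compound 1 to compound 4 (0.56 log units; beyond the scatter), and exchanging bromo for chloro gives an at least 6.5-fold higher number from compound 3 to compound 4 (0.81 log units; beyond the scatter). Two halogens at the same place therefore need not act alike, since bromo stays within the scatter of the unsubstituted compound 1, while chloro moves beyond it towards weaker inhibition. The result for compound 4 is a limit of the assay and not a number, as is that of compound 2, so the step between those two cannot be read and the full size of the loss stays unknown: the limit of > 25000 nM in this assay, at which 2 of the 4 values shown sit.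

Still open, as far as these compounds go, is whether a fluoro or an amine group at this place would side with bromo or with chloro, and whether chloro would behave the same way elsewhere on that ring. The gap between the two halogens also rests on a single pair of compounds, and no repeat of it on another core is shown.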